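Amide substituent exchange in the series: outlook for compound 4

A few compounds are considered here, and "the series" means these few. Any claim that something is new, unique, unknown or untested is made for them only; others in the source may bear on it.

Compound 1 `COc1ccc2c(=O)c(/C=C/C(=O)NCc3ccccc3)coc2c1`: in a functional assay on L02 cells (Homo sapiens) for inhibition, read by MTT assay, with a stated time of 48 h (on this read-out lower numbers stand for stronger inhibition and higher numbers for weaker inhibition), compound 1 gives > 200000 nM, which is a limit of the assay.
Compound 2 `COc1ccc2c(=O)c(/C=C/C(=O)NCc3cccc(F)c3)coc2c1`: in this assay compound 2 gives > 200000 nM, again a limit.
Compound 3 `COc1ccc2c(=O)c(/C=C/C(=O)NCc3ccccc3F)coc2c1`: in this assay compound 3 gives > 200000 nM, also a limit.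

Compound 3 therefore stands at no number of its own but at the limit of > 200000 nM in this assay, at which 3 of the 3 values shown sit, together with compound 1 and compound 2. The three steps among the measured compounds, a step that the two limits leave unreadable from compound 1 to compound 2, a step that the two limits leave unreadable from compound 1 to compound 3 and a step that the two limits leave unreadable from compound 2 to compound 3, cannot be sized, since both ends of each lie at the limit.

Compound 4 `COc1ccc2c(=O)c(/C=C/C(=O)Nc3ccc(Cl)cc3)coc2c1` differs from compound 3 by 4-chlorophenyl in place of 2-fluorobenzyl on an amide-type nitrogen. Within the data shown here, no measured step involves an exchange of this kind; the only comparisons available are the three unreadable ones above, so they give no direction and no size for this change. With every measured value at the limit, the expected outcome for compound 4 in this assay is likewise a limit rather than a number; compound 4 is estimated at 200000 nM, within a range of 60000 nM to 600000 nM. The step from compound 3 implied by this estimate, a number no higher from compound 3 to compound 4 (the limit leaves the size open), is expected to be none beyond the scatter.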

Compound 4, half-maximal inhibitory concentration: > 200000 nM
Compound 4: a limit, no number; the forecaster's own chance of this, stated with the estimate: 75%; the middle value lies on the limit itself.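

No step from compound 1, compound 2 or compound 3 to compound 4 can be read, since both ends of each lie at a limit: the limit of > 200000 nM in this assay, at which 4 of the 4 values shown sit.

The compounds shown leave open whether any amide substituent on the shared core gives a number in this assay, and how 4-chlorophenyl truly compares with benzyl, 3-fluorobenzyl or 2-fluorobenzyl.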